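Cyano in Place of Hydroxy at the Adenosine Receptor

This account rests on a few compounds, and the source may have more. Where it says the series, first, only, none or still open, it means among the compounds named here.

Compound 1, `CCCn1c(=O)c2nc(-c3ccc(O)cc3)[nH]c2n(C)c1=O`: 1.28 nM
Compound 2, `CCCn1c(=O)n(C)c(=O)c2[nH]c(-c3ccc(O)cc3)nc21`: 2.54 nM

Both were measured in an assay on Cortex for displacement of a labelled ligand from adenosine receptor A1 (Rattus norvegicus); a higher number here means a weaker inhibitor, a lower number a stronger inhibitor. Compound 1 shows the lowest of the two numbers, but compound 2 lies within the scatter of it, so the two cannot be ranked. Compound 3, `CCCn1c(=O)c2nc(-c3ccc(C#N)cc3)[nH]c2n(C)c1=O`, differs from compound 1 in one place: cyano in place of hydroxy on an aromatic carbon. No measured pair shows this change, so the size of the step in this assay is not known from shown steps; a modest weakening is expected, possibly none beyond the scatter. Compound 3 is expected to give 5 nM, with a range from 1.5 nM to 20 nM. The expected step is a 3.9-fold higher number from compound 1 to compound 3 (0.59 log units; beyond the scatter).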

Compound 3, inhibition constant: 5.95 nM
The estimate for compound 3 lay 1.2-fold (0.08 log units) below the measured number; low and high end bracket the measured number.
By their numbers in this assay, from the lowest: compounds 1 and 2 (each within the scatter of the next); then compound 3.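

In this assay, cyano in place of hydroxy gives a 4.6-fold higher number from compound 1 to compound 3 (0.67 log units; beyond the scatter) and so a modest weakening, beyond the scatter. The hydroxy is therefore not essential at this position: compound 3 gives 5.95 nM in the same low range, although its cyano carries no hydrogen-bond donor. Nothing measured here explains the size of this step. Still open, going by these compounds, is how an amine, a methoxy or a carboxylic acid on this aromatic carbon would compare, and whether the same change on compound 2 would give a similar step.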